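Extending compound 3 with a phenyl group

This account rests on a few compounds, and the source may have more. Where it says the series, first, only, none or still open, it means among the compounds named here.

Measured in a functional assay on B16-F10 cells (Mus musculus) for antiproliferative activity, read by MTT assay, with a stated time of 48 h; a higher number here means a weaker inhibitor, a lower number a stronger inhibitor:

- compound 1 `COc1ccc(/C=C/c2cc(OC)cc(OC)c2/C=C/C(=O)c2ccc(Cl)c(Cl)c2)cc1` gives 7.5 ug/mL
- compound 2 `COc1ccc(/C=C/c2cc(OC)cc(OC)c2/C=C/C(=O)c2ccc(Br)cc2)cc1` gives 6.5 ug/mL
- compound 3 `COc1ccc(/C=C/c2cc(OC)cc(OC)c2/C=C/C(=O)c2ccccc2)cc1` gives 3.7 ug/mL

Compound 3 has a plain phenyl on its carbonyl carbon. Two steps fix its place among the three: a 1.8-fold lower number from compound 2 to compound 3 (0.24 log units; within the scatter) and a 2.0-fold lower number from compound 1 to compound 3 (0.31 log units; beyond the scatter), so only the second clears the usual scatter.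

Compound 4 `COc1ccc(/C=C/c2cc(OC)cc(OC)c2/C=C/C(=O)c2ccc(-c3ccccc3)cc2)cc1` differs in one place, with phenyl in place of hydrogen on an aromatic carbon, para to a large group (phenyl in place of hydrogen on an aromatic carbon). The nearest guides are the 4-bromophenyl of compound 2 at 6.5 ug/mL and the 3,4-dichlorophenyl of compound 1 at 7.5 ug/mL. Both carry substituents on that ring and both show higher numbers than compound 3, but neither carries a second ring, so the guide is rough. A modest move toward a higher number in this assay is therefore expected, possibly no more than the scatter. The expected size is a 1.6-fold higher number from compound 3 to compound 4 (0.21 log units; within the scatter), and this is only an estimate. For compound 4 the estimated value is 6 ug/mL, with an expected range from 3 ug/mL to 12 ug/mL.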

Compound 4, half-maximal inhibitory concentration: 10.6 ug/mL
Compound 4: middle estimate off by 1.8-fold (0.25 log units), on the low side; low and high end bracket the measured number.
By their numbers in this assay, from the lowest: compounds 3, 2, 1 and 4 (each within the scatter of the next, the first and the last beyond it).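

In this assay, phenyl in place of hydrogen on this aromatic carbon, para to a large group, gives a 2.9-fold higher number from compound 3 to compound 4 (0.46 log units; beyond the scatter) and so a second ring here does not match the plain phenyl of compound 3. Set against the substituted rings, the 4-phenylphenyl group cannot be told apart from 4-bromophenyl, with a 1.6-fold higher number from compound 2 to compound 4 (0.21 log units; within the scatter) as the step, or from 3,4-dichlorophenyl, with a 1.4-fold higher number from compound 1 to compound 4 (0.15 log units; within the scatter) as the step. No measurement shown here explains this result.

The compounds shown carry only halogens or phenyl on this ring, so it remains open how a methoxy group, an amine or a carboxylic acid would behave at the same carbon. Also open, from the compounds shown here alone, is whether a ring joined through a longer chain would read differently from the directly attached phenyl.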